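Replacing fluoro with cyano on the indazole of compound 2

The compounds below may be only part of what the source reports. "The series", "measured", "known", "first", "only" and "open" are said of these compounds alone.

Measured compounds:
compound 1, `CC/C(=C(/c1ccc(/C=C/C(=O)O)cc1)c1ccc2[nH]nc(F)c2c1)c1ccccc1`, 14000 ng.h/mL
compound 2, `CC/C(=C(/c1ccc(/C=C/C(=O)O)cc1)c1ccc2[nH]ncc2c1F)c1ccccc1`, 8200 ng.h/mL

In an ADME assay on the whole organism (strain CD-1) for pharmacokinetics, with Mus musculus as the target, at a dose of 10 mg/kg by the oral route (a lower number here means less compound in the circulation, a higher number more compound in the circulation at the dose given), compound 2 gives the lower of the two numbers, with compound 1 the nearest neighbour; the step of a 1.7-fold lower number from compound 1 to compound 2 (0.23 log units; within the scatter) lies within the scatter, so the two compounds cannot be ordered. Compound 3, `CC/C(=C(/c1ccc(/C=C/C(=O)O)cc1)c1ccc2[nH]ncc2c1C#N)c1ccccc1`, differs from compound 2 by cyano in place of fluoro on an aromatic carbon, with the cyano carrying one hydrogen-bond acceptor that the fluoro lacked. Going by the values given here, no measured step involves a cyano group: the only step available concerns the position of a fluoro on the core, and it stayed within the scatter. Nothing here therefore points to a change beyond the scatter in this assay for compound 3, and the estimate leans only slightly toward a lower number because of the size of a 1.7-fold lower number from compound 1 to compound 2 (0.23 log units; within the scatter). Compound 3 is expected to show a step of a 1.2-fold lower number from compound 2 to compound 3 (0.07 log units; within the scatter). The estimate for compound 3 in this assay is 7000 ng.h/mL, with a range from 2500 ng.h/mL to 20000 ng.h/mL.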

Compound 3, area under the concentration-time curve: 500 ng.h/mL
For compound 3 the middle estimate is 14-fold (1.15 log units) above the measured one; the whole stated range lies above it.
By their numbers in this assay, from the lowest: compound 3; then compounds 2 and 1 (each within the scatter of the next).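

In this assay, going by these compounds alone, the change from fluoro to cyano on this aromatic carbon, ortho to a fused ring and ortho to a large group, gives a 16-fold lower number from compound 2 to compound 3 (1.21 log units; beyond the scatter) and so brings the first step beyond the scatter in this short series. Within the data shown here, the only earlier step, a 1.7-fold lower number from compound 1 to compound 2 (0.23 log units; within the scatter), concerned where a fluoro sat on the core and could not be read as a change. The new result shows that the number does respond to the identity of the group on this carbon, and no measurement at hand accounts for the size of the step.

On these data alone, whether the step is particular to cyano or would also follow another group on this carbon, such as chloro, methyl or methoxy, stays open. Equally open, as far as these compounds go, is whether cyano on the carbon that bears fluoro in compound 1 would give a step of similar size.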